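The compounds below may be only part of what the source reports. "The series", "measured", "known", "first", "only" and "open" are said of these compounds alone.

In a functional assay on HeLa cells (Homo sapiens) for cytotoxicity, read by XTT assay, with a stated time of 72 h (on this read-out higher numbers stand for weaker inhibition and lower numbers for stronger inhibition), three compounds built on one shared core have been measured. Compound 1 `COc1cc(/C(=N/NC(C)=O)c2ccc3c(ccn3C)c2)cc(OC)c1OC` gives 2300 nM. Compound 2 `CN/N=C(/c1cc(OC)c(OC)c(OC)c1)c1ccc2c(ccn2C)c1` reaches only a limit of the assay, recorded as > 1000 nM. Compound 3 `COc1cc(/C(=N/C(=O)OC(C)(C)C)c2ccc3c(ccn3C)c2)cc(OC)c1OC` also reaches only a limit, recorded as > 1000 nM. Because (the limit of > 1000 nM in this assay, at which 2 of the 3 values shown sit), neither a step that the limit leaves unreadable from compound 1 to compound 3 nor a step that the two limits leave unreadable from compound 2 to compound 3 can be given a size, and a step that the limit leaves unreadable from compound 1 to compound 2 is likewise unreadable. Compound 3 therefore stands at the limit, with no number of its own.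

Compound 4 `COc1cc(/C(=N\C(=O)OC(C)(C)C)c2ccc3c(ccn3C)c2)cc(OC)c1OC` keeps every atom and bond of compound 3; the change is the two compounds have the same atoms and bonds and differ only in configuration as drawn: 1 of 1 stereo elements differ; a double bond is drawn E in compound 3 and Z in compound 4. Going by the values given here, none of the measured pairs compares two such drawn configurations, so the measured steps offer no direction for this change, and the only firm point is that compound 3 sits at a limit. The step from compound 3 to compound 4 is estimated as a step that the limit leaves unreadable from compound 3 to compound 4. Compound 4 is expected to give 3000 nM, with a range from 1000 nM to 10000 nM, and most likely again only a limit.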

Compound 4, half-maximal inhibitory concentration: > 1000 nM
Compound 4: only a limit was reported; the forecaster's own chance of this, stated with the estimate: 65%; the middle value does not contradict the limit.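

No step can be read between compound 3 and compound 4, because neither has a number of its own: the limit of > 1000 nM in this assay, at which 3 of the 4 values shown sit. From the compounds shown here alone, whether drawing the double bond E or Z makes any difference in this assay stays open, as does the actual strength of compound 3 and compound 4.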